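Halogen for methyl on the pendant aryl in the series

A few compounds are considered here, and "the series" means these few. Any claim that something is new, unique, unknown or untested is made for them only; others in the source may bear on it.

Measured so far in a functional assay on SK-MEL-2 cells (Homo sapiens) for cytotoxicity; a lower number here means a stronger inhibitor, a higher number a weaker inhibitor:
- compound 1 `Cc1ccc(C2CNC(=O)N2S(=O)(=O)c2ccc3c(c2)CCC3)cc1`: 88600 nM
- compound 2 `Cc1ccc(C2CNC(=O)N2S(=O)(=O)c2ccc(C)cc2)cc1`: 234000 nM
- compound 3 `Cc1ccc(S(=O)(=O)N2C(=O)NCC2c2ccc(Br)cc2)cc1`: 80000 nM

Compound 1 stands second highest of the three numbers. Its nearest neighbour is compound 3, within the scatter of it, while compound 2 lies beyond the scatter, with the higher number.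

Compound 4 `O=C1NCC(c2ccc(Cl)cc2)N1S(=O)(=O)c1ccc2c(c1)CCC2` is not yet measured. Against compound 1 the difference is chloro in place of methyl on an aromatic carbon.

Within the data shown here, one measured step bears on this change: a 2.9-fold lower number from compound 2 to compound 3 (0.47 log units; beyond the scatter). That step swaps methyl for a halogen at the same place, though the halogen there is bromo rather than chloro, and the sulfonyl aryl differs from that of compound 1, so the carry-over is uncertain. On the shared core a halogen in that place gave a modest lowering once; a step of similar size or somewhat smaller is expected here, in the lowering direction, though a result within the scatter cannot be excluded.

For compound 4 the expected value in this assay is 40000 nM, with a range of 15000 nM to 110000 nM, which is an estimated step of a 2.2-fold lower number from compound 1 to compound 4 (0.35 log units; beyond the scatter).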

Compound 4, half-maximal inhibitory concentration: 161000 nM
Beside the measured number, compound 4's estimate is 4.0-fold (0.60 log units) below it; the whole stated range lies below it.
By their numbers in this assay, from the lowest: compounds 3, 1, 4 and 2 (each within the scatter of the next, the first and the last beyond it).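

In this assay, chloro in place of methyl on the pendant aryl of compound 1 gives a 1.8-fold higher number from compound 1 to compound 4 (0.26 log units; within the scatter), so on this core the swap cannot be told apart from no change. The lowering seen with bromo, a 2.9-fold lower number from compound 2 to compound 3 (0.47 log units; beyond the scatter), therefore does not recur here, and replacing methyl with a halogen at this position gives no general lowering across the two pairs shown. No measurement at hand accounts for the two pairs reading differently.

Still open, on these data alone, is whether that contrast follows the halogen, bromo against chloro, or the sulfonyl aryl, as the two steps differ in both. Also open, as far as these compounds go, is how a methoxy group, an amine or a carboxylic acid in this position would read in this assay.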